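The source may report more compounds than this note shows. Statements on the series, on what has been measured and on what is new or still open speak of the compounds shown alone.

In a functional assay (aorta) with Oryctolagus cuniculus as the target (on this read-out higher numbers stand for weaker binding and lower numbers for tighter binding), compound 3 `CC(=O)Nc1ccc(OCCCN2CCC(C(c3ccc(F)cc3)c3ccc(F)cc3)CC2)cc1` gives 12.6 nM. Compound 1 `COc1cc(C(C)O)ccc1OCCCN1CCC(C(c2ccc(F)cc2)c2ccc(F)cc2)CC1` gives 10 nM, which is close, with a 1.3-fold higher number from compound 1 to compound 3 (0.10 log units; within the scatter). Compound 2 `N#Cc1ccc(OCCCN2CCC(C(c3ccc(F)cc3)c3ccc(F)cc3)CC2)cc1` gives 5.01 nM, and it is the only one clearly apart, with a 2.5-fold higher number from compound 2 to compound 3 (0.40 log units; beyond the scatter). Compound 4 `COc1ccc(OCCCN2CCC(C(c3ccc(F)cc3)c3ccc(F)cc3)CC2)cc1` carries methoxy in place of acetamido on an aromatic carbon. The closest guide is the swap between compound 2 and compound 3 on that same aromatic carbon, which was modest. The group change between compound 1 and compound 2 was also small, with a 2.0-fold lower number from compound 1 to compound 2 (0.30 log units; within the scatter). A slightly lower number is therefore expected, though nothing beyond the scatter, with a 1.6-fold lower number from compound 3 to compound 4 (0.20 log units; within the scatter) as the estimated step. For compound 4 the estimated value is 8 nM, with an expected range from 3.5 nM to 18 nM.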

Compound 4, dissociation constant: 2.51 nM
Beside the measured number, compound 4's estimate is 3.2-fold (0.50 log units) above it; measured number below the stated range.
By their numbers in this assay, from the lowest: compounds 4, 2, 1 and 3 (each within the scatter of the next, the first and the last beyond it).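

In this assay, methoxy in place of acetamido on this aromatic carbon, para to a large group, gives a 5.0-fold lower number from compound 3 to compound 4 (0.70 log units; beyond the scatter) and so removes the amide hydrogen-bond donor with a clear gain. Methoxy in place of cyano gives a 2.0-fold lower number from compound 2 to compound 4 (0.30 log units; within the scatter) and so leaves these two groups unranked. The plain 4-methoxyphenyl in place of 4-(1-hydroxyethyl)-2-methoxyphenyl gives a 4.0-fold lower number from compound 1 to compound 4 (0.60 log units; beyond the scatter) and so shows that a low number here needs neither the extra methoxy nor the 1-hydroxyethyl group.

From the compounds shown here alone, how an amine, a carboxylic acid or a longer chain such as ethoxy would fare on this carbon stays open. Nothing available explains why these steps occur.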